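Lipophilicity of a Sulfonamide Pair and a Dimethylphenyl Analogue

This account rests on a few compounds, and the source may have more. Where it says the series, first, only, none or still open, it means among the compounds named here.

Measured compounds:
compound 1 `CCc1ccc(N(CC(C)C)S(=O)(=O)c2ccc3c(c2)C(O)CC(C2CCN(S(C)(=O)=O)CC2)O3)cc1` gives 3.22
compound 2 `CC(C)CN(c1ccccc1F)S(=O)(=O)c1ccc2c(c1)C(O)CC(C1CCOCC1)O2` gives 3.39

The two measured compounds were examined in a physicochemical assay for lipophilicity, at pH 7.4; on this read-out higher numbers stand for higher lipophilicity and lower numbers for lower lipophilicity. Compound 2 has the higher of the two numbers, yet its value sits within the scatter of the value of compound 1, so the two compounds cannot be ordered on this read-out. Among the compounds with values here, no step between them is computed, since they differ in more than one place.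

Compound 3 `Cc1ccc(N(CC(C)C)S(=O)(=O)c2ccc3c(c2)C(O)CC(C2CCOCC2)O3)c(C)c1` has not yet been measured in this assay. It differs from compound 2 in one place: 2,4-dimethylphenyl in place of 2-fluorophenyl on a sulfonamide nitrogen No measured step of this kind is available among the compounds shown. Compound 3 is nevertheless expected to give a step of a number 0.71 log units higher from compound 2 to compound 3 (beyond the scatter) in this assay, that is, an increase beyond the scatter, with the value of compound 2 at 3.39 as its starting point. Compound 3 is therefore estimated at 4.1, in a range from 3.6 to 4.6.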

Compound 3, distribution coefficient: 4.19
Beside the measured number, compound 3's estimate is 0.09 log units below it; the measured number falls inside the stated range.
By their numbers in this assay, from the lowest: compounds 1 and 2 (each within the scatter of the next); then compound 3.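

In this assay, within the data shown here, 2,4-dimethylphenyl in place of 2-fluorophenyl on a sulfonamide nitrogen gives a number 0.80 log units higher from compound 2 to compound 3 (beyond the scatter), the only step in this set that comes from a change in one place. It shows that the aryl group at this position can move the read-out beyond the scatter, which compound 1 and compound 2 could not show, as they differ in more than one place and cannot be ordered. The change takes the group from 7 to 8 heavy atoms and replaces fluorine with carbon only, while the counted hydrogen-bond donors and acceptors stay the same.

The compounds shown leave open whether both methyl groups are needed for this step, and what an aminophenyl or carboxyphenyl group would give at this position. Nothing available bears on why the read-out moves by this amount.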